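The source may hold more compounds than are shown below. What is called first, only, known or untested is meant among the compounds shown, and "the series" means these compounds.

Series in a functional assay on MCF7 cells (Homo sapiens) for inhibition, read by fluorescence, with a stated time of 72 h; a higher number here means a weaker inhibitor of growth, a lower number a stronger inhibitor of growth:
Compound 1 `COc1ccc(Nc2nc(N[C@H]3CC[C@H](N)CC3)nc3c2ncn3CCC(C)C)c(OC)c1`: 6300 nM
Compound 2 `CC(C)CCn1cnc2c(Nc3ccc(Cl)cc3)nc(N[C@H]3CC[C@H](N)CC3)nc21`: 2700 nM
Compound 3 `CCCCCCn1cnc2c(Nc3ccc(Cl)cc3)nc(N[C@H]3CC[C@H](N)CC3)nc21`: not yet measured

Of the two measured compounds, compound 2 has the lower number, 2700 nM. The next change keeps its 4-chlorophenyl and alters the chain: butyl in place of isopropyl on a saturated chain carbon, two bonds along the chain from an aromatic nitrogen. This is butyl in place of isopropyl on a saturated chain carbon, two bonds along the chain from an aromatic nitrogen; cut one bond further out, it reads isopentyl to hexyl.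

Among the measured compounds shown here, the only measured step, a 2.3-fold lower number from compound 1 to compound 2 (0.37 log units; beyond the scatter), is modest and sits on a nitrogen on an aromatic ring, not on this chain. For the measured compounds named here, no measured step therefore bears directly on the change, and no step beyond the scatter is expected in this assay. The expected step is a 1.1-fold lower number from compound 2 to compound 3 (0.03 log units; within the scatter). Compound 3 is estimated at 2500 nM, with an expected range of 1000 nM to 6500 nM.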

Compound 3, concentration for 50% growth inhibition: 4200 nM
Beside the measured number, compound 3's estimate is 1.7-fold (0.23 log units) below it; low and high end bracket the measured number.
By their numbers in this assay, from the lowest: compounds 2, 3 and 1 (each within the scatter of the next, the first and the last beyond it).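

In this assay, among the compounds shown here, this place, on a saturated chain carbon, two bonds along the chain from an aromatic nitrogen, now has its first measured step, as the earlier compounds varied only the group on the other nitrogen. Butyl in place of isopropyl, which turns isopentyl into hexyl with the 4-chlorophenyl held constant, gives a 1.6-fold higher number from compound 2 to compound 3 (0.19 log units; within the scatter) and so separates the straight chain from the branched one by no more than repeat measurements would. At this place, this single pair therefore shows tolerance of the added carbon and the lost branch. No available evidence accounts for the result.

As far as these compounds go, whether a shorter chain such as propyl, a longer chain such as octyl, or a chain ending in an amine or a carboxylic acid would move the number at this place stays open. Also open, from the compounds shown here alone, is whether hexyl behaves the same way alongside the 2,4-dimethoxyphenyl of compound 1.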